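Aryl imine series on the shared core: nitro analogue pending

This account rests on a few compounds, and the source may have more. Where it says the series, first, only, none or still open, it means among the compounds named here.

Measured so far:
compound 1, `Brc1ccc(/C=N/c2nnc(SCc3c[se]c(-c4ccccc4)n3)s2)cc1`: 14800 nM
compound 2, `CN(C)c1ccc(/C=N/c2nnc(SCc3c[se]c(-c4ccccc4)n3)s2)cc1`: 80300 nM

Two compounds of the shared core have been run in a functional assay on MCF7 cells (Homo sapiens) for antiproliferative activity, read by CCK-8 assay; a higher number here means a weaker inhibitor, a lower number a stronger inhibitor. Compound 1 `Brc1ccc(/C=N/c2nnc(SCc3c[se]c(-c4ccccc4)n3)s2)cc1` gives 14800 nM in this assay. Going by the values given here, compound 2 `CN(C)c1ccc(/C=N/c2nnc(SCc3c[se]c(-c4ccccc4)n3)s2)cc1` gives 80300 nM and so stands with the highest of the two numbers, its only neighbour being compound 1, at a 5.4-fold higher number from compound 1 to compound 2 (0.73 log units; beyond the scatter) for the exchange of dimethylamino for bromo on the aromatic carbon.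

Compound 3 `O=[N+]([O-])c1ccc(/C=N/c2nnc(SCc3c[se]c(-c4ccccc4)n3)s2)cc1` is the next member, not yet measured. Its difference from compound 2 is nitro in place of dimethylamino on an aromatic carbon, on an aromatic carbon of a six-membered aromatic ring of carbon only, para to a large group. Among the compounds with values here, no measured step involves nitro, so the single step from compound 1 to compound 2 is the only guide, and it shows that a change at this position can move the number beyond the scatter. The direction for nitro is open; the working expectation is a number between the two measured values, nearer compound 1. Compound 3 is therefore estimated at 20000 nM in this assay, within 5000 nM to 80000 nM, which means an expected step of a 4.0-fold lower number from compound 2 to compound 3 (0.60 log units; beyond the scatter).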

Compound 3, half-maximal inhibitory concentration: 49100 nM
Compound 3: middle estimate off by 2.5-fold (0.39 log units), on the low side, within the range that was stated.
By their numbers in this assay, from the lowest: compound 1; then compounds 3 and 2 (each within the scatter of the next).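

In this assay the exchange of dimethylamino for nitro gives a 1.6-fold lower number from compound 2 to compound 3 (0.21 log units; within the scatter) and so does not separate these two groups, each of 3 heavy atoms, at this aromatic carbon. The exchange of bromo for nitro gives a 3.3-fold higher number from compound 1 to compound 3 (0.52 log units; beyond the scatter) and shows that bromo now stands apart from two different groups rather than from one, leaving compound 1 as the strongest of the three in this assay and compound 2 and compound 3 level with each other. No measured property of these groups is available to account for this.

As far as these compounds go, it remains open whether the lower number of compound 1 belongs to bromo alone or would also be seen with another halogen such as chloro or iodo, or with a small carbon group such as methyl, on the same aromatic carbon. Also open, from the compounds shown here alone, is whether a carboxylic acid or a primary amine at this place would stay level with compound 2 and compound 3 or move the number beyond the scatter in either direction.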